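The source may report more compounds than this note shows. Statements on the series, on what has been measured and on what is new or still open speak of the compounds shown alone.

Compound 3 `CCCNS(=O)(=O)c1ccc(Nc2ncc3c(n2)N(c2ccn(C)n2)C(CC)C(=O)N3C)cc1` carries a propyl group on its sulfonamide nitrogen, and in a functional assay on MCF7 cells (Homo sapiens) for antiproliferative activity, read by CCK-8 assay, with a stated time of 72 h (on this read-out higher numbers stand for weaker inhibition of growth and lower numbers for stronger inhibition of growth), compound 3 gives 3000 nM, the lowest of the two numbers measured. Its nearest neighbour is compound 1 `CCC1C(=O)N(C)c2cnc(Nc3ccc(S(=O)(=O)NCCCO)cc3)nc2N1c1ccn(C)n1`, which in this assay gives 21600 nM; the step of a 7.2-fold lower number from compound 1 to compound 3 (0.86 log units; beyond the scatter) is the only one measured. Compound 2 `CCC1C(=O)N(C)c2cnc(Nc3ccc(S(=O)(=O)NCCO)cc3)nc2N1c1ccn(C)n1` in this assay is "not active" (no number reported). Compound 4 `CCC1C(=O)N(C)c2cnc(Nc3ccc(S(N)(=O)=O)cc3)nc2N1c1ccn(C)n1` differs from compound 3 by hydrogen in place of propyl on a sulfonamide nitrogen. For the measured compounds named here, no measured step removes the whole substituent from this nitrogen, so the single modest step from compound 1 to compound 3 is only loosely related. Compound 4 is therefore expected to show a step of a 1.7-fold higher number from compound 3 to compound 4 (0.22 log units; within the scatter), and in this assay compound 4 is estimated at 5000 nM, within a range from 1500 nM to 20000 nM.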

Compound 4, concentration for 50% growth inhibition: 36600 nM
Compound 4: middle estimate off by 7.3-fold (0.86 log units), on the low side; the whole stated range lies below it.
By their numbers in this assay, from the lowest: compound 3; then compounds 1 and 4 (each within the scatter of the next).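

In this assay, the sulfonamide nitrogen proves sensitive to its substituent: hydrogen in place of propyl gives a 12-fold higher number from compound 3 to compound 4 (1.09 log units; beyond the scatter) and so loses most of the growth inhibition seen with compound 3. A terminal hydroxy makes the longer substituent no better than hydrogen here, as hydrogen in place of 3-hydroxypropyl gives a 1.7-fold higher number from compound 1 to compound 4 (0.23 log units; within the scatter) and leaves these two compounds indistinguishable. Nothing available here explains either result. From the compounds shown here alone, whether a butyl chain would match propyl remains open, as does the effect of an amine at the end of the propyl chain.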